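Triazole-linked aryl pairs: amino to methoxy, cytotoxicity unchanged

The source may hold more compounds than are shown below. What is called first, only, known or untested is meant among the compounds shown, and "the series" means these compounds.

The study follows a small set of triazole-linked aryl pairs in a functional assay on MDA-MB-231 cells (Homo sapiens) for cytotoxicity, read by MTT assay; on this read-out lower numbers stand for stronger inhibition and higher numbers for weaker inhibition. Compound 1 `COc1cc(-n2cc(-c3ccc(N)cc3)nn2)cc(OC)c1OC` carries a 4-aminophenyl on one side of the triazole and a trimethoxyphenyl on the other. In this assay compound 1 gives only a limit, > 10000 nM. Compound 2 `COc1ccc(-c2cn(-c3cc(OC)c(OC)c(OC)c3)nn2)cc1` differs from compound 1 by methoxy in place of amino on an aromatic carbon. In this assay compound 2 likewise gives only a limit, > 10000 nM. The step that the two limits leave unreadable from compound 1 to compound 2 is therefore unreadable, since both ends sit at the same limit (the limit of > 10000 nM in this assay, at which 3 of the 3 values shown sit).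

Compound 3 `COc1ccc(-n2cc(-c3ccc(N)cc3)nn2)cc1O` places the 4-aminophenyl on the other nitrogen of the triazole and replaces the trimethoxyphenyl with a ring bearing one methoxy and one hydroxyl; the difference between the two cores is not broken down here. In this assay compound 3 also gives only a limit, > 10000 nM.

Compound 4 `COc1ccc(-c2cn(-c3ccc(OC)c(O)c3)nn2)cc1` has not yet been measured. It differs from compound 3 by methoxy in place of amino on an aromatic carbon, the same change that separates compound 1 from compound 2, made at a place described in the same words. Since the corresponding step in this assay was left unreadable, and since all three values shown sit at the limit (the limit of > 10000 nM in this assay, at which 3 of the 3 values shown sit), the step from compound 3 to compound 4 is expected to be a step that the limit leaves unreadable from compound 3 to compound 4, with most of the probability resting on another limit. On that basis compound 4 is estimated at 20000 nM, within a range from 5000 nM to 100000 nM.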

Compound 4, half-maximal inhibitory concentration: > 100 nM
Compound 4 gave a limit, no number; the forecaster's own chance of this, stated with the estimate: 85%; the middle value lies beyond the limit too.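

In this assay compound 4 gives > 100 nM, which is a limit and not a number. Compound 3 also stands only at a limit, so no step can be read between compound 3 and compound 4, just as none can between compound 1 and compound 2. The compounds shown leave open whether methoxy in place of amino on an aromatic carbon shifts the value in this assay at all, and by how much.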